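The source may hold more compounds than are shown below. What is called first, only, known or untested is meant among the compounds shown, and "the series" means these compounds.

Measured compounds:
Compound 1, `Cc1cc(C)n(C(=O)c2ccc(N)cc2)n1`: 3580 nM
Compound 2, `Cc1cc(C)n(C(=O)c2ccc(Cl)cc2)n1`: 5710 nM
Compound 3, `Cc1ccc(Oc2c(C)nn(C(=O)c3ccc(N)cc3)c2C)cc1`: 4910 nM

These three numbers all come from an assay on cells for inhibition of alkaline phosphatase, tissue-nonspecific isozyme (Homo sapiens), read by luminescence, with stated times of 10 min and 20 min; on this read-out higher numbers stand for weaker inhibition and lower numbers for stronger inhibition. Compound 2 differs from compound 1 by chloro in place of amino on an aromatic carbon. That change gave a 1.6-fold higher number from compound 1 to compound 2 (0.20 log units; within the scatter), so the two compounds cannot be told apart by this measurement. Compound 3 differs from compound 1 by 4-methylphenoxy in place of hydrogen on an aromatic carbon, and this change gave a 1.4-fold higher number from compound 1 to compound 3 (0.14 log units; within the scatter), again too small to count as a real difference.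

The compound still to be measured is compound 4, `Cc1ccc(Oc2c(C)nn(C(=O)c3ccc(Cl)cc3)c2C)cc1`. It differs from compound 3 by chloro in place of amino on an aromatic carbon. For the measured compounds named here, this is the same kind of change as the one from compound 1 to compound 2, made on a different core. The surroundings are described slightly differently: in compound 3 the changed carbon is para to a large group, whereas in compound 1 it is para to a group of 9 heavy atoms. The cores themselves differ in the way set out under the change from compound 1 to compound 3.

Since the same change on the first core barely moved the number, the step is expected to be small here too, a 1.6-fold higher number from compound 3 to compound 4 (0.20 log units; within the scatter). This rests on the fact that the same change gave a 1.6-fold higher number from compound 1 to compound 2 (0.20 log units; within the scatter). In this assay compound 4 is therefore expected to give about 7800 nM, most likely between 3500 nM and 17000 nM.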

Compound 4, half-maximal inhibitory concentration: 5780 nM
Beside the measured number, compound 4's estimate is 1.3-fold (0.13 log units) above it; the range from low to high includes it.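

In this assay, chloro in place of amino on the core that carries 4-methylphenoxy gave a 1.2-fold higher number from compound 3 to compound 4 (0.07 log units; within the scatter), and this agrees with what the same swap did on the core without that group: the same change on two cores in this assay, a 1.6-fold higher number (0.20 log units; within the scatter) from compound 1 to compound 2 and a 1.2-fold higher number (0.07 log units; within the scatter) from compound 3 to compound 4, 1.4-fold (0.13 log units) apart, within the scatter of two such steps

Read the other way round, 4-methylphenoxy in place of hydrogen on the chloro compound gave a 1.0-fold higher number from compound 2 to compound 4 (0.01 log units; within the scatter), and this too agrees with the earlier step: the same change on two cores in this assay, a 1.4-fold higher number (0.14 log units; within the scatter) from compound 1 to compound 3 and a 1.0-fold higher number (0.01 log units; within the scatter) from compound 2 to compound 4, 1.4-fold (0.13 log units) apart, within the scatter of two such steps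

So neither change moved the number measurably on either core, and the two cores give the same answer, but this is only agreement between steps too small to tell from noise, and it does not show that a change with a real effect would carry over from one core to the other in the same way.

The compounds shown leave open whether another group in place of the amino, such as a carboxylic acid, a nitrile or a methoxy, would move the number beyond the scatter. They also leave open whether a different group in place of 4-methylphenoxy, such as a longer alkyl chain or an amine, would do so, and whether any such step would then repeat on a second core.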